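Hydroxyphenyl series: furan-2-yl in place of phenyl

The source may hold more compounds than are shown below. What is called first, only, known or untested is meant among the compounds shown, and "the series" means these compounds.

Measured so far in a functional assay on HeLa cells (Homo sapiens) for cytotoxicity, read by ELISA, with a stated time of 2 days; a lower number here means a stronger inhibitor, a higher number a weaker inhibitor
- compound 1 `Oc1ccc(-c2cc(-c3ccccc3)cc(-c3cccs3)n2)cc1` gives 1700 nM
- compound 2 `Oc1ccc(-c2cc(-c3ccccc3)cc(-c3cccnc3)n2)cc1` gives 13600 nM
- compound 3 `Oc1cccc(-c2cc(-c3ccccc3)nc(-c3ccccc3)c2)c1` gives 15100 nM

Compound 3 at 15100 nM lies within the scatter of compound 2 at 13600 nM. Compound 1 at 1700 nM has the lower number, and its gap to compound 3 is well outside the scatter.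

The next step leads to compound 4 `Oc1cccc(-c2cc(-c3ccccc3)nc(-c3ccco3)c2)c1`, with furan-2-yl in place of phenyl on an aromatic carbon, next to the ring nitrogen furan-2-yl in place of phenyl on an aromatic carbon in the core.

Within the data shown here, one measured step bears on this, and only indirectly. It is an 8.0-fold higher number from compound 1 to compound 2 (0.90 log units; beyond the scatter) for pyridin-3-yl in place of thiophen-2-yl, so the compound with the five-membered ring has the lower number. Neither furan-2-yl nor phenyl takes part in that step, and compounds 1 and 2 also differ from compound 3 elsewhere, so it transfers only loosely.

A shift to a lower number in this assay is therefore expected, smaller than that measured step, and no shift beyond the scatter remains possible. The estimate means a 2.5-fold lower number from compound 3 to compound 4 (0.40 log units; beyond the scatter) as the expected step. Compound 4 is estimated at 6000 nM with 1800 nM to 16000 nM as the expected range.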

Compound 4, half-maximal inhibitory concentration: 10900 nM
Estimate against measurement, compound 4: 1.8-fold (0.26 log units) below, and the stated range covers the measured number.
By their numbers in this assay, from the lowest: compound 1; then compounds 4, 2 and 3 (each within the scatter of the next).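

In this assay, furan-2-yl in place of phenyl on the aromatic carbon next to the ring nitrogen gives a 1.4-fold lower number from compound 3 to compound 4 (0.14 log units; within the scatter), so this change does not separate the two rings at this position with the other groups of compound 3 held fixed. Going from a six-membered aromatic ring of carbon only to a five-membered aromatic ring with 1 hetero atom, and from 0 hydrogen-bond acceptors to 1 hydrogen-bond acceptor on this substituent, is therefore not enough here to repeat a step such as an 8.0-fold higher number from compound 1 to compound 2 (0.90 log units; beyond the scatter), which involves other rings on a differently substituted core. No measurement on hand accounts for the absence of a clear shift at this position.

Open, as far as these compounds go, is whether thiophen-2-yl and pyridin-3-yl differ at this position with the 3-hydroxyphenyl group in place as they do in compounds 1 and 2, since only a matched pair on this core could show whether that gap carries over. Also open, from the compounds shown here alone, is whether a non-aromatic substituent at the same carbon, such as a morpholine, an aminomethyl group or a carboxylic acid, would move the number beyond the scatter, where the two aromatic rings do not.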